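Series notes: piperidin-4-yl in place of hydrogen, compound 3

This account rests on a few compounds, and the source may have more. Where it says the series, first, only, none or still open, it means among the compounds named here.

Measured so far in a functional assay on LNCaP cells (Homo sapiens) for cytotoxicity, read by MTT assay, with a stated time of 48 h; on this read-out higher numbers stand for weaker inhibition and lower numbers for stronger inhibition:
compound 1 `Oc1ccc(-c2nc(-c3c[nH]c4ccccc34)co2)cc1`: 449000 nM
compound 2 `c1ccc2c(-c3cocn3)c[nH]c2c1`: 382000 nM

Compound 2 has the lowest of the two numbers in this assay, but a 1.2-fold lower number from compound 1 to compound 2 (0.07 log units; within the scatter) falls within the scatter, so the two stand level. Compound 3 `c1ccc2c(-c3coc(C4CCNCC4)n3)c[nH]c2c1` arises by piperidin-4-yl in place of hydrogen on an aromatic carbon. Among the measured compounds shown here, no measured step bears on this change; the only measured step, a 1.2-fold lower number from compound 1 to compound 2 (0.07 log units; within the scatter), concerns a different position and is within the scatter. No step beyond the scatter is therefore expected, and the estimated step is a 1.3-fold lower number from compound 2 to compound 3 (0.10 log units; within the scatter). Compound 3 is estimated at 300000 nM, with a range from 80000 nM to 800000 nM.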

Compound 3, half-maximal inhibitory concentration: 476000 nM
Compound 3: middle estimate off by 1.6-fold (0.20 log units), on the low side; low and high end bracket the measured number.
By their numbers in this assay, from the lowest: compounds 2, 1 and 3 (each within the scatter of the next).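

In this assay, piperidin-4-yl on the aromatic carbon next to the ring nitrogen and next to the ring oxygen gives a 1.2-fold higher number from compound 2 to compound 3 (0.10 log units; within the scatter), so a non-aromatic ring at this position brings no step beyond the scatter. Piperidin-4-yl in place of 4-hydroxyphenyl on the same carbon gives a 1.1-fold higher number from compound 1 to compound 3 (0.03 log units; within the scatter), leaving hydrogen and both groups level here. No evidence at hand accounts for this flat picture.

Still open, on these data alone, is whether a carboxylic acid, an open-chain amine or a longer chain on this carbon would bring a step beyond the scatter.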